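The source may hold more compounds than are shown below. What is called first, only, known or untested is meant among the compounds shown, and "the series" means these compounds.

Compound 1 `CC(C)n1c(SCc2ccccc2Cl)nc2cc(NC(=O)C3CC3)ccc21` — > 10000 nM (a limit)
Compound 2 `CCCn1c(SCc2cc([N+](=O)[O-])ccc2OC)nc2cc(NC(=O)NC(C)(C)C)cc(C(=O)OC)c21` — 280 nM
Compound 3 `CCCn1c(SCc2cc([N+](=O)[O-])ccc2OC)nc2cc(NC(=O)NC(C)(C)C)cc(C(=O)N(C)C)c21` — 200 nM
Compound 4 `CCCn1c(SCc2cc([N+](=O)[O-])ccc2OC)nc2cc(NC(=O)NC(C)(C)C)cc(C(=O)NCc3ccncc3)c21` — not yet measured

In an assay on isolated protein for inhibition of Gonadotropin-releasing hormone receptor (Rattus norvegicus) (a lower number here means a stronger inhibitor, a higher number a weaker inhibitor), compound 1 reports only a limit, > 10000 nM, not a number; this is the situation described by the limit of > 10000 nM in this assay, at which 1 of the 3 values shown sits. Compound 2 gives 280 nM in this assay. Compound 3 gives 200 nM and so carries the lowest number shown, but the step of a 1.4-fold lower number from compound 2 to compound 3 (0.15 log units; within the scatter) is within the scatter, so compound 2 and compound 3 cannot be told apart on these numbers.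

Compound 4 differs from compound 3 in one place: ((pyridin-4-yl)methyl)amino in place of dimethylamino on a carbonyl carbon. For the measured compounds named here, no measured step makes this kind of exchange at the carbonyl carbon. Going by the values given here, the only step that touches that position, a 1.4-fold lower number from compound 2 to compound 3 (0.15 log units; within the scatter), was within the scatter, which is the sole guide available. On that basis a step of little size is expected in this assay for compound 4, in neither direction beyond the scatter, though a larger group entering there leaves more room for surprise than the earlier exchange did.

Compound 4 is therefore estimated at 200 nM, with a range from 60 nM to 700 nM. That estimate corresponds to an expected step of no change at the digits printed from compound 3 to compound 4 (within the scatter), within the scatter.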

Compound 4, half-maximal inhibitory concentration: 35 nM
Compound 4: the middle estimate sits 5.7-fold (0.76 log units) above what was measured; measured number below the stated range.
By their numbers in this assay, from the lowest: compound 4; then compounds 3 and 2 (each within the scatter of the next). At a limit, above all of these: compound 1.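

In this assay, the carbonyl carbon now proves able to shift the number beyond the scatter, which the exchange of methoxy for dimethylamino had not shown: ((pyridin-4-yl)methyl)amino gives a 5.7-fold lower number from compound 3 to compound 4 (0.76 log units; beyond the scatter), and set against methoxy it gives an 8.0-fold lower number from compound 2 to compound 4 (0.90 log units; beyond the scatter). This single exchange changes several things at once, since the entering group brings a six-membered aromatic ring with a hetero atom, a hydrogen-bond donor and a hydrogen-bond acceptor, none of which dimethylamino has. Nothing among the measurements available bears on which of these features goes with the lower number, so the gain can be tied only to the group as a whole.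

Methylamino would test the amide hydrogen on its own, while benzylamino, which carries a plain benzene ring in place of the pyridine, would show whether the ring nitrogen matters at all. Moving that ring nitrogen, as in ((pyridin-3-yl)methyl)amino, or lengthening the link with ((pyridin-4-yl)ethyl)amino, would show how closely the number depends on the exact shape of the group.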